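This account rests on a few compounds, and the source may have more. Where it says the series, first, only, none or still open, it means among the compounds named here.

Measured compounds:
Compound 1 `Cc1ccc(COc2ccc(C(=O)/C=C/c3ccc(Cl)cc3)cc2)cc1` gives > 50000 nM in a functional assay on CAL-51 cells (Homo sapiens) for inhibition, read by sulforhodamine B assay, with a stated time of 3 days; a lower number here means a stronger inhibitor of growth, a higher number a weaker inhibitor of growth; this is a limit of the assay, not a number.
Compound 2 `O=C(/C=C/c1ccc(Cl)cc1)c1ccc(OCc2ccccc2)cc1` gives > 50000 nM in this assay; again a limit, not a number.

Within the data shown here, compound 1 thus stands at the limit of this assay with no measured value of its own, and the only other value shown is also a limit, so compound 1 cannot be placed relative to anything. Among the measured compounds shown here, the single measured step, a step that the two limits leave unreadable from compound 1 to compound 2, is hydrogen in place of methyl on an aromatic carbon and is unreadable, since both ends sit at the limit, as the limit of > 50000 nM in this assay, at which 2 of the 2 values shown sit, records.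

Compound 3 `Cc1ccc(COc2ccc(C(=O)/C=C/c3ccc(F)cc3)cc2)cc1` differs from compound 1 by fluoro in place of chloro on an aromatic carbon. For the measured compounds named here, no measured step bears on this change: the step from compound 1 to compound 2 alters a different part of the molecule and its size is not readable anyway. Both measured compounds sit at the limit, so no direction can be read for compound 3 in this assay beyond the scatter. Compound 3 is therefore expected to remain at or near the limit, with the step that the limit leaves unreadable from compound 1 to compound 3 expected to be small. Compound 3 is estimated at 60000 nM, within 15000 nM to 200000 nM.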

Compound 3, concentration for 50% growth inhibition: > 50000 nM
Compound 3: no number, only a limit; the forecaster's own chance of this, stated with the estimate: 80%; the middle value does not contradict the limit.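

Compound 3, like compound 1 and compound 2, gives only a limit and not a number, so the change from chloro to fluoro between compound 1 and compound 3 yields no readable step: the limit of > 50000 nM in this assay, at which 3 of the 3 values shown sit.

The compounds shown leave open how compound 1 and compound 3 actually compare, and whether any change to this series gives a measurable value in this assay.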